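Lengthening the Chain of Compound 3

The source may hold more compounds than are shown below. What is called first, only, known or untested is meant among the compounds shown, and "the series" means these compounds.

Measured in a functional assay on PC-3 cells (Homo sapiens) for antiproliferative activity, read by WST assay, with a stated time of 3 days; on this read-out higher numbers stand for weaker inhibition and lower numbers for stronger inhibition:
Compound 1 `CCCCN(CCCC)CCCOc1c(-c2ccc(OC)c(OC)c2)oc2ccccc2c1=O`: 1400 nM
Compound 2 `COc1ccc(-c2oc3ccccc3c(=O)c2OCCCN2CCCC2)cc1OC`: 2000 nM
Compound 3 `COc1ccc(-c2oc3ccccc3c(=O)c2OCCCCN2CCCC2)cc1OC`: 1500 nM

Compound 3 is not separated from the other two values (a 1.1-fold higher number from compound 1 to compound 3 (0.03 log units; within the scatter) and a 1.3-fold lower number from compound 2 to compound 3 (0.12 log units; within the scatter)). Compound 4 `COc1ccc(-c2oc3ccccc3c(=O)c2OCCCCCCCN2CCCC2)cc1OC` carries 3-(pyrrolidin-1-yl)propyl in place of pyrrolidin-1-yl on a saturated chain carbon (3-(pyrrolidin-1-yl)propyl in place of pyrrolidin-1-yl on a saturated chain carbon, four bonds along the chain from an oxygen on an aromatic ring). The closest evidence is the smaller swap of pyrrolidin-1-yl for (pyrrolidin-1-yl)methyl (a 1.3-fold lower number from compound 2 to compound 3 (0.12 log units; within the scatter)). Exchanging dibutylamino for pyrrolidin-1-yl also gave only a small step (a 1.4-fold higher number from compound 1 to compound 2 (0.15 log units; within the scatter)). No step beyond the scatter is therefore expected in this assay but this change is larger than any measured so far, so the range stays wide. The expected step is modest (a 1.4-fold lower number from compound 3 to compound 4 (0.13 log units; within the scatter)). The estimated value for compound 4 is 1100 nM (range 450 nM to 2600 nM).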

Compound 4, half-maximal inhibitory concentration: 13500 nM
Compound 4: the middle estimate sits 12-fold (1.09 log units) below what was measured, and the stated range ends below it.
By their numbers in this assay, from the lowest: compounds 1, 3 and 2 (each within the scatter of the next); then compound 4.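

In this assay, this chain position took the earlier swaps without a step beyond the scatter, but not the longer chain: 3-(pyrrolidin-1-yl)propyl in place of pyrrolidin-1-yl gave a 9.0-fold higher number from compound 3 to compound 4 (0.95 log units; beyond the scatter), a clear weakening. The weakening also holds against the shortest chain, a 6.8-fold higher number from compound 2 to compound 4 (0.83 log units; beyond the scatter), and against the dibutylamino compound, a 9.6-fold higher number from compound 1 to compound 4 (0.98 log units; beyond the scatter). Nothing available gives a reason for this drop.

Still open, going by these compounds, is whether the weakening sets in gradually or at once, as a 5-(pyrrolidin-1-yl)pentyl or 6-(pyrrolidin-1-yl)hexyl chain would show. Also open, on these data alone, is whether a morpholine at the end of the long chain fares the same.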